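A few compounds are considered here, and "the series" means these few. Any claim that something is new, unique, unknown or untested is made for them only; others in the source may bear on it.

Measured so far:
compound 1 `O=C(O)CCCC/C=C(/c1ccc(Br)cc1)c1cccnc1` — in an assay (Equus caballus) for inhibition of Thromboxane-A synthase (Homo sapiens), using microsomes (a lower number here means a stronger inhibitor, a higher number a weaker inhibitor), compound 1 gives 82 nM
compound 2 `CC(C)(CCCC/C=C(\c1ccccc1)c1cccnc1)C(=O)O` — in this assay compound 2 gives 45 nM

Compound 1 holds the higher of the two numbers, but compound 2 sits close to it and the gap between them lies within the scatter, so nothing is read from their order. Going by the values given here, no pair of measured compounds differs in only one place, so no single-point step is known for this assay.

The next compound, compound 3 `Cc1ccc(/C(=C/CCCCC(=O)O)c2cccnc2)cc1`, differs from compound 1 by methyl in place of bromo on an aromatic carbon. The shared core and the chain with its acid are kept; only the group on the six-membered aromatic ring of carbon only is exchanged. Nothing measured tells how this group matters, so the expectation for this assay is a small step toward a higher number, not clearly beyond the scatter. Compound 3 is expected to give 110 nM, between 45 nM and 270 nM. The expected step of a 1.3-fold higher number from compound 1 to compound 3 (0.13 log units; within the scatter) is thus one that stays near the scatter.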

Compound 3, half-maximal inhibitory concentration: 85 nM
For compound 3 the middle estimate is 1.3-fold (0.11 log units) above the measured one; measured number inside the range.
By their numbers in this assay, from the lowest: compounds 2, 1 and 3 (each within the scatter of the next).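

In this assay the exchange of bromo for methyl, on an aromatic carbon para to a large group, gives a 1.0-fold higher number from compound 1 to compound 3 (0.02 log units; within the scatter) and so stays within the scatter. Going by these compounds alone, this is the first single-place step, and it shows that the 4-bromophenyl and 4-methylphenyl forms cannot be told apart by this read-out, with the shared core and the chain with its acid kept. Nothing on hand bears on the reason for this result.

Within the data shown here, whether this position would tolerate a group of another kind, such as an amine or a carboxylic acid, remains open, since bromo and methyl are the only pair compared here. From the compounds shown here alone, compound 2 differs from compound 1 and compound 3 in more than one place, so the part played by its chain remains open too.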